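The source may report more compounds than this note shows. Statements on the series, on what has been measured and on what is new or still open speak of the compounds shown alone.

In a functional assay on CCRF-CEM cells (Homo sapiens) for antiproliferative activity (a lower number here means a stronger inhibitor of growth, a higher number a weaker inhibitor of growth), compound 1 (`COCCCCCCCCCCCCCCC/C=C1/CC(CO)(COC(=O)C(C)(C)C)OC1=O`) gives < 0.1 ug/mL, which is a limit of the assay and not a number. Among the compounds with values here, compound 2 (`COC(=O)CCCCCCCCCCCCCC/C=C1\CC(CO)(COC(=O)C(C)(C)C)OC1=O`) gives 0.691 ug/mL, the only actual number so far, so its standing against the other compound cannot be ranked on a numerical scale. Compound 3 (`CCCCCOCCCCCCC/C=C1\CC(CO)(COC(=O)C(C)(C)C)OC1=O`) is not yet measured. It carries pentyloxy in place of 7-(methoxycarbonyl)heptyl on a saturated chain carbon, seven bonds along the chain from a double-bonded chain carbon. Within the data shown here, no measured step between compounds differing in one place is available to size this change in this assay, so no shift beyond the scatter is expected in either direction. The estimated change is a 1.2-fold lower number from compound 2 to compound 3 (0.06 log units; within the scatter). For compound 3 the expected value is 0.6 ug/mL, with an estimated range of 0.15 ug/mL to 2.5 ug/mL.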

Compound 3, concentration for 50% growth inhibition: 0.877 ug/mL
For compound 3 the middle estimate is 1.5-fold (0.16 log units) below the measured one, and the stated range covers the measured number.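

In this assay, within the data shown here, the exchange gives a 1.3-fold higher number from compound 2 to compound 3 (0.10 log units; within the scatter), the first readable step at this place. On a saturated chain carbon, seven bonds along the chain from a double-bonded chain carbon, pentyloxy and 7-(methoxycarbonyl)heptyl are therefore not told apart, although the group that leaves has 11 heavy atoms and the group that enters has 6. The methoxycarbonyl end is thus not needed to keep the read-out within the scatter of the value of compound 2.

Among these compounds, compound 1 stands at a limit and not a number, and it differs from the other compounds in more than one place, so it sizes no step: the limit of < 0.1 ug/mL in this assay, at which 1 of the 3 values shown sits. Whether the same holds for an amine, a terminal carboxylic acid or a longer chain at this place remains open.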